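The source may hold more compounds than are shown below. What is called first, only, known or untested is meant among the compounds shown, and "the series" means these compounds.

Measured so far in a functional assay on cells (Lymphocyte, Homo sapiens) for inhibition, read by flow cytometry, using a membrane potential dye, with a stated time of 16 h, tested at 500 nM; a lower number here means a weaker effect, a higher number a stronger effect of the compound at the concentration tested:
compound 1 `CCCCCCCCCCCCCCCCc1nc(N2CCC2)c(C)c(C)c1O` — 85%
compound 2 `CCCCCCCCCCCCCCCCCCCc1c(C)c(N(C)C)nc(C)c1O` — 64%

Compound 1 stands highest of the two numbers in this assay; compound 2 sits lower by a gap beyond the usual scatter. Among the measured compounds shown here, the two share only parts of their build, so their values show a difference but no single step can be drawn from them.

Compound 3 `CCCCCCCCCCCCCCCCc1nc(N(C)C)c(C)c(C)c1O` is not yet measured. It differs from compound 1 in one place: dimethylamino in place of azetidin-1-yl on an aromatic carbon. The dimethylamino group also occurs in compound 2, but compound 2 differs from compound 3 in further places, so its lower value gives only a loose hint.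

For the measured compounds named here, with no measured step of this kind, the expectation is a small change, if any, downward rather than upward, with the step of a number 9 percentage points lower from compound 1 to compound 3 (within the scatter) expected to lie near the scatter. Compound 3 is estimated at 76% in this assay, within a range from 58% to 90%.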

Compound 3, a percentage reported as activity, at one concentration (the size of the read-out at that concentration, not a potency): 92%
Estimate against measurement, compound 3: 16 percentage points below; measured number outside the range, above it.
By their numbers in this assay, from the lowest: compound 2; then compounds 1 and 3 (each within the scatter of the next).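

In this assay, among the compounds shown here, the exchange at the aromatic carbon next to the ring nitrogen gives the first readable step at this position: a number 7 percentage points higher from compound 1 to compound 3 (within the scatter). On the core of compound 1, this read-out at this single concentration therefore does not separate azetidin-1-yl from dimethylamino, and the four-membered ring is not needed to keep the effect in this pair. No measurement is available that bears on the reason for this result.

As far as these compounds go, it remains open whether a larger ring such as piperidin-1-yl, or a morpholin-4-yl or plain amino group, would keep the effect at this position. The separate contribution of the long chain also remains open, since no step among these compounds isolates a change in chain length or in the ring's methyl groups.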